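The source may report more compounds than this note shows. Statements on the series, on what has been measured and on what is new or still open speak of the compounds shown alone.

Measured so far in a physicochemical assay for lipophilicity, measured as octanol-water partition (on this read-out lower numbers stand for lower lipophilicity and higher numbers for higher lipophilicity), are these compounds:
- compound 1 `Cc1cc(OCCCO)cc(C)c1Cl` gives 3.38
- compound 2 `CC(O)COc1ccc(Cl)cc1Cl` gives 2.75
- compound 3 `OCC(O)COc1ccc(Cl)cc1Cl` gives 1.99

Compound 1 holds the highest of these three numbers. Compound 4 `Cc1cc(OCC(C)O)cc(C)c1Cl` has the same atoms joined differently, with 1-hydroxyethyl in place of 2-hydroxyethyl on a saturated chain carbon bound to an oxygen on an aromatic ring so that 3-hydroxypropyl becomes 2-hydroxypropyl. Among the compounds with values here, the one measured step is a number 0.76 log units lower from compound 2 to compound 3 (beyond the scatter) and it adds a hydroxy, whereas here nothing is added, so it bears only loosely. Within the data shown here, no measured pair shows this exact swap. The expected step is a number 0.13 log units lower from compound 1 to compound 4 (within the scatter) in this assay and no clear change is anticipated. For compound 4 the estimate is 3.25 with 2.95 to 3.55 as the expected range.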

Compound 4, partition coefficient: 3.18
Compound 4: the middle estimate sits 0.07 log units above what was measured; low and high end bracket the measured number.
By their numbers in this assay, from the lowest: compound 3; then compound 2; then compounds 4 and 1 (each within the scatter of the next).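

Changing 3-hydroxypropyl to 2-hydroxypropyl on the core of compound 1 gives, in this assay, a number 0.20 log units lower from compound 1 to compound 4 (within the scatter) and so no clear change. Within the data shown here, the only earlier step, a number 0.76 log units lower from compound 2 to compound 3 (beyond the scatter), added a hydroxy, whereas this change adds nothing and only joins the same atoms differently. Nothing measured here offers an explanation for this result.

Still open, going by these compounds, is whether the same swap gives a similar step on another core. On these data alone, it is also open how an amine, a carboxylic acid or a longer chain at this place would read.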